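The compounds below may be only part of what the source reports. "The series", "measured", "known", "first", "only" and "open" are said of these compounds alone.

Measured compounds:
Compound 1 `CC(C)C(NS(=O)(=O)Cc1ccccc1)C(=O)N1CCC(c2ccc(Cl)cc2)CC1` gives 303 nM in an assay on THP-1 cells for displacement of a labelled ligand from C-C chemokine receptor type 1 (Homo sapiens); on this read-out lower numbers stand for stronger inhibition and higher numbers for weaker inhibition.
Compound 2 `CC(C)C(NC(=O)c1ccc2ccccc2c1)C(=O)N1CCC(c2ccc(Cl)cc2)CC1` gives 80 nM in this assay.
Compound 3 `CC(C)[C@@H](NC(=O)NCc1ccccc1)C(=O)N1CCC(c2ccc(Cl)cc2)CC1` gives 180 nM in this assay.

Compound 2 has the lowest number of the three in this assay; compound 3 stands above it by a step beyond the scatter, and compound 1 stands further above still. Compound 4 `CC(C)C(NC(=O)Oc1ccccc1)C(=O)N1CCC(c2ccc(Cl)cc2)CC1` differs from compound 2 by phenoxy in place of naphthalen-2-yl on a carbonyl carbon. Among the measured compounds shown here, no pair of measured compounds shares this change, so the expectation rests on the spread of the three numbers alone. Compound 1 at 303 nM and compound 3 at 180 nM both lie beyond the scatter above compound 2, and the step of a 2.5-fold higher number from compound 2 to compound 4 (0.40 log units; beyond the scatter) is accordingly expected to go toward a higher number, of moderate size. Compound 4 is estimated at 200 nM, with a range from 70 nM to 600 nM.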

Compound 4, half-maximal inhibitory concentration: 265 nM
Estimate against measurement, compound 4: 1.3-fold (0.12 log units) below, and the stated range covers the measured number.
By their numbers in this assay, from the lowest: compound 2; then compounds 3, 4 and 1 (each within the scatter of the next).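

Phenoxy in place of naphthalen-2-yl on the carbonyl carbon gives a 3.3-fold higher number from compound 2 to compound 4 (0.52 log units; beyond the scatter) in this assay and so puts a size on a change at this place. Phenoxycarbonyl in place of benzylsulfonyl on the amine nitrogen gives a 1.1-fold lower number from compound 1 to compound 4 (0.06 log units; within the scatter) and these two groups are not told apart on this read-out. Nothing available explains either step.

Compounds 2 and 4 cannot separate the second aromatic ring from the entering oxygen, so phenyl or benzyloxy on that carbonyl carbon would be informative. As far as these compounds go, how an amine or a carboxylic acid on the phenoxy ring would behave also remains open.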